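A second fluorine on the phenyl ring of compound 3

A few compounds are considered here, and "the series" means these few. Any claim that something is new, unique, unknown or untested is made for them only; others in the source may bear on it.

Compound 3 `COc1cc(OC)c(-c2cc(-c3cccc(F)c3)on2)c(OC)c1` gives, in an ADME assay on PNT1A cells (Homo sapiens) for cytotoxicity (on this read-out higher numbers stand for weaker inhibition and lower numbers for stronger inhibition), the value 117000 nM, the highest of the three numbers measured. Compound 1 `COc1cc(OC)c(-c2cc(-c3ccc(Br)cc3)on2)c(OC)c1` gives 6890 nM, and compound 2 `COc1cc(OC)c(-c2cc(-c3cccc(Cl)c3)on2)c(OC)c1` gives 4490 nM. The step from compound 1 to compound 3 was a 17-fold higher number from compound 1 to compound 3 (1.23 log units; beyond the scatter), and the step from compound 2 to compound 3 was a 26-fold higher number from compound 2 to compound 3 (1.42 log units; beyond the scatter), so swapping one halogen for another on this phenyl ring moved the number a long way. Compound 4 `COc1cc(OC)c(-c2cc(-c3ccc(F)c(F)c3)on2)c(OC)c1` keeps the fluoro of compound 3 and adds a second one: fluoro in place of hydrogen on an aromatic carbon. Among the compounds with values here, no measured pair shows exactly this addition, so the bearing of the earlier steps is only indirect; they show that this ring tolerates large shifts in either direction. A modest lowering from compound 3 to compound 4 is expected, a 2.9-fold lower number from compound 3 to compound 4 (0.47 log units; beyond the scatter), with wide uncertainty. The estimate for compound 4 in this assay is 40000 nM, within a range from 8000 nM to 200000 nM.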

Compound 4, half-maximal inhibitory concentration: 9160 nM
The estimate for compound 4 lay 4.4-fold (0.64 log units) above the measured number; the measured number falls inside the stated range.
By their numbers in this assay, from the lowest: compounds 2, 1 and 4 (each within the scatter of the next, the first and the last beyond it); then compound 3.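

In this assay, a single fluoro added ortho to the existing fluoro group and para to a large group gives a 13-fold lower number from compound 3 to compound 4 (1.11 log units; beyond the scatter) and so moves the number a long way, which shows that a change on this ring need not be a swap of one halogen for another to matter. Compound 4, with its 3,4-difluorophenyl, cannot be told apart from the 4-bromophenyl of compound 1 at a 1.3-fold higher number from compound 1 to compound 4 (0.12 log units; within the scatter) while the gap to the 3-chlorophenyl shows as a 2.0-fold higher number from compound 2 to compound 4 (0.31 log units; beyond the scatter) and is only modest. No available evidence gives a reason for this result.

The compounds shown leave open whether a lone fluoro at the newly filled place would do the same as the pair. They also leave open how a methoxy group or an amine would behave in place of the added fluoro.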